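Extending methyl to benzyl: what compound 4 may show

A few compounds are considered here, and "the series" means these few. Any claim that something is new, unique, unknown or untested is made for them only; others in the source may bear on it.

compound 1 `C[S+]([O-])/C=C/c1cc(=O)c2ccccc2o1` gives 1900 nM
compound 2 `Cc1c(/C=C/[S+](C)[O-])oc2ccccc2c1=O` gives 1500 nM
compound 3 `CCCCC(=O)Oc1ccc2oc(/C=C/[S+](C)[O-])cc(=O)c2c1` gives 2400 nM

In a functional assay on A549 cells (Homo sapiens) for cytotoxicity, with a stated time of 48 h (on this read-out lower numbers stand for stronger inhibition and higher numbers for weaker inhibition), compound 2 gives 1500 nM and lies within the usual scatter of the two other compounds, so the three values set up no order among them. Compound 4 `C[S+]([O-])/C=C/c1oc2ccccc2c(=O)c1Cc1ccccc1` departs from compound 2 in one place: phenyl in place of hydrogen on a saturated chain carbon bound to an aromatic carbon with phenyl in place of hydrogen on a saturated chain carbon bound to an aromatic carbon, which turns methyl into benzyl.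

For the measured compounds named here, two measured steps bear on this change, both only indirectly. Methyl in place of hydrogen on an aromatic carbon gave a 1.3-fold lower number from compound 1 to compound 2 (0.10 log units; within the scatter) and (butylcarbonyl)oxy in place of hydrogen on an aromatic carbon gave a 1.3-fold higher number from compound 1 to compound 3 (0.10 log units; within the scatter) in this assay as well. Going by the values given here, neither step adds a phenyl, and no measured compound carries one, so the direction stays open and the range is kept wide. The expected change is a 1.3-fold higher number from compound 2 to compound 4 (0.10 log units; within the scatter) and no step beyond the scatter is expected. For compound 4 the estimated value is 1900 nM with an expected range from 800 nM to 4500 nM in this read-out.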

Compound 4, half-maximal inhibitory concentration: 1300 nM
The estimate for compound 4 lay 1.5-fold (0.16 log units) above the measured number, and the stated range covers the measured number.
By their numbers in this assay, from the lowest: compounds 4, 2, 1 and 3 (each within the scatter of the next).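

Phenyl in place of hydrogen on a saturated chain carbon bound to an aromatic carbon gave a 1.2-fold lower number from compound 2 to compound 4 (0.06 log units; within the scatter) in this assay and so shows that this position can carry benzyl as well as methyl with no step beyond the scatter. Also in this assay there is a 1.5-fold lower number from compound 1 to compound 4 (0.16 log units; within the scatter), so the benzyl of compound 4 stays within the scatter of the hydrogen of compound 1 as well. Nothing at hand explains why this change leaves the number within the scatter.

As far as these compounds go, whether an amine, a carboxylic acid or a longer chain in place of benzyl would move the number beyond the scatter stays open. The compounds shown also leave open whether any group at this position can separate itself from compound 1 at all.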